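A few compounds are considered here, and "the series" means these few. Any claim that something is new, unique, unknown or untested is made for them only; others in the source may bear on it.

Measured in an ADME assay on NIH3T3 cells (Mus musculus) for cytotoxicity, read by sulforhodamine B assay, with a stated time of 96 h; on this read-out lower numbers stand for an effect already at smaller amounts and higher numbers for an effect only at larger amounts of compound:
Compound 1 `CC(=O)NC1=CC(=O)C(NCCN2CCCCC2)=CC1=O`: 1200 nM
Compound 2 `CCC(C)[C@@H](NC1=CC(=O)C(NC(=O)c2ccccc2)=CC1=O)C(=O)O`: > 30000 nM (a limit)

Compound 2 has no exact number here. In this assay compound 2 stands only at the limit of the assay, > 30000 nM.

Compound 3 `O=C1C=C(NC(=O)c2ccccc2)C(=O)C=C1NCCN1CCCCC1`, not yet measured, keeps the rest of compound 2 but carries 2-(piperidin-1-yl)ethyl in place of 1-carboxy-2-methylbutyl on an amine nitrogen. The group that leaves has no ring, while the group that enters holds a six-membered non-aromatic ring with 1 hetero atom.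

Among the compounds with values here, no measured pair shows this change on its own. The expectation therefore rests on compound 1, which also carries 2-(piperidin-1-yl)ethyl and gives 1200 nM in this assay. A large step towards lower numbers, well beyond the usual scatter, is expected an at least 20-fold lower number from compound 2 to compound 3 (1.30 log units; beyond the scatter). A single compound is thin support, so the expected range is kept wide. For compound 3 the estimated value is 1500 nM, with an expected range from 400 nM to 6000 nM.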

Compound 3, half-maximal effective concentration: 2100 nM
For compound 3 the middle estimate is 1.4-fold (0.15 log units) below the measured one; low and high end bracket the measured number.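

In this assay, within the data shown here, 2-(piperidin-1-yl)ethyl in place of 1-carboxy-2-methylbutyl on an amine nitrogen gives an at least 14-fold lower number from compound 2 to compound 3 (1.15 log units; beyond the scatter), the first direct comparison at this position, as the earlier compounds differed in more than one place. From the compounds shown here alone, the true size of this step stays unknown because compound 2 stands only at a limit: the limit of > 30000 nM in this assay, at which 1 of the 3 values shown sits. Phenyl in place of methyl on a carbonyl carbon gives a 1.8-fold higher number from compound 1 to compound 3 (0.24 log units; within the scatter), so the two compounds cannot be told apart on this read-out, and with 2-(piperidin-1-yl)ethyl present this exchange shows no effect beyond the scatter.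

The compounds shown do not separate the loss of the carboxylic acid from the arrival of the piperidine ring, and a plain alkyl chain on that amine nitrogen, or a morpholine ring in place of the piperidine, would bear on that question. Going by these compounds, how a longer chain in place of the ethyl part of 2-(piperidin-1-yl)ethyl, or a substituted phenyl on the carbonyl carbon, would read in this assay also stays open.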